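Cyclobutyl to Cyclopentyl Ester Step in Two Cores

A few compounds are considered here, and "the series" means these few. Any claim that something is new, unique, unknown or untested is made for them only; others in the source may bear on it.

Measured so far:
compound 1 `CC1=C(C(=O)OC2CCC2)C(c2ccco2)NC(=O)N1` gives 19%
compound 2 `CC1=C(C(=O)OC2CCCC2)C(c2ccco2)NC(=O)N1` gives 1%
compound 3 `CC1=C(C(=O)OC2CCC2)C(c2cccs2)NC(=O)N1` gives 24%

Three compounds carry a number in an assay on membranes from CHO cells for displacement of a labelled ligand from adenosine receptor A1 (Homo sapiens), read by scintillation counting, with a stated time of 60 min, tested at 1 uM; a higher number here means more inhibition at the concentration tested (going by the name of the read-out), a lower number less inhibition; one further compound does not yet.

Compound 1 and compound 3 share everything except the group on the saturated ring carbon: thiophen-2-yl in place of furan-2-yl on a saturated ring carbon. The step of a number 5 percentage points higher from compound 1 to compound 3 (within the scatter) is within the scatter, so the two cores behave alike on this read-out as far as these two compounds show.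

Compound 1 and compound 2 differ only in the ester: cyclopentyl in place of cyclobutyl on an oxygen next to a carbonyl group. Here the step of a number 18 percentage points lower from compound 1 to compound 2 (beyond the scatter) is beyond the scatter, the one clear movement among the three measured compounds, and it runs downward.

Compound 4 `CC1=C(C(=O)OC2CCCC2)C(c2cccs2)NC(=O)N1` is the not yet measured member. It differs from compound 3 in exactly this way: cyclopentyl in place of cyclobutyl on an oxygen next to a carbonyl group. The place line reads the same as for the pair compound 1 to compound 2, so the change is the same change, appearing in two pairs, once on the core of compound 1 and once on the core of compound 3.

Given that compound 1 and compound 3 sit within the scatter of each other in this assay, the expectation is that compound 4 repeats the step seen before, and the expected step of a number 18 percentage points lower from compound 3 to compound 4 (beyond the scatter) is set because a number 18 percentage points lower from compound 1 to compound 2 (beyond the scatter) is the only measured step for this change. Compound 4 is therefore estimated at 6% in this assay, with the expected range running from -6% to 20%. A single precedent carries this estimate; it cannot show whether the ester step reads the same on the core of compound 3.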

Compound 4, a percentage reported as inhibition, at one concentration (the size of the read-out at that concentration, not a potency): 9%
Compound 4: middle estimate off by 3 percentage points, on the low side; measured number inside the range.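

The change from cyclobutyl to cyclopentyl on an oxygen next to a carbonyl group gives a number 15 percentage points lower from compound 3 to compound 4 (beyond the scatter), so in this assay it carries from the core of compound 1 to the core of compound 3: the same change on two cores in this assay, a number 18 percentage points lower (beyond the scatter) from compound 1 to compound 2 and a number 15 percentage points lower (beyond the scatter) from compound 3 to compound 4, 3 percentage points apart, within the scatter of two such steps

The swap of furan-2-yl for thiophen-2-yl gives a number 8 percentage points higher from compound 2 to compound 4 (within the scatter), and it reads alike with either ester: the same change on two cores in this assay, a number 5 percentage points higher (within the scatter) from compound 1 to compound 3 and a number 8 percentage points higher (within the scatter) from compound 2 to compound 4, 3 percentage points apart, within the scatter of two such steps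

This agreement rests on two pairs for each change, and every number is inhibition at a single concentration rather than a potency, so it does not show that either step would hold on a further core or that the two changes would combine in the same way with other groups.

The compounds shown leave open how a cyclopropyl, a cyclohexyl or an open-chain tert-butyl group on that oxygen would read, and whether the ester step would keep its size with a phenyl in place of the furan-2-yl or thiophen-2-yl. They also leave open how potency would compare across these compounds, and whether an amide in place of the ester would follow the same steps.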